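The compounds below may be only part of what the source reports. "The series", "measured", "known", "first", "only" and "open" are said of these compounds alone.

Measured so far in an in vitro functional assay on Sf9 cells for agonist activity at histamine H2 receptor (Homo sapiens); on this read-out lower numbers stand for an effect already at smaller amounts and higher numbers for an effect only at larger amounts of compound:
compound 1 `Cc1nc(N)sc1CCCN/C(N)=N/C(=O)CCCCCCCCC(=O)/N=C(\N)NCCCc1sc(N)nc1C`, compound 1 gives 7.76 nM;
compound 2 `N/C(=N\C(=O)CCCCCCCCC(=O)/N=C(\N)NCCCc1c[nH]cn1)NCCCc1c[nH]cn1`, compound 2 gives 6.17 nM;
compound 3 `Cc1nc(N)sc1CCCN/C(N)=N/C(=O)CCCCCCCCC(=O)/N=C(\N)NCCCc1cnc(N)s1`, compound 3 gives 13.8 nM.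

Compound 3 has the highest number of the three in this assay; compound 1 is nearest, compound 2 furthest, the latter beyond the scatter.

Compound 4 `Cc1nc(N)sc1CCCN/C(N)=N/C(=O)CCCCCCCCC(=O)/N=C(\N)NCCCc1c[nH]cn1` carries 1H-imidazol-4-yl in place of 2-amino-1,3-thiazol-5-yl on a saturated chain carbon, three bonds along the chain from an amine nitrogen. For the measured compounds named here, no measured step covers this exchange. Going by the values given here, the one measured step, a 1.8-fold higher number from compound 1 to compound 3 (0.25 log units; within the scatter), concerns a methyl and does not bear on it. What the numbers show is that compound 1, with two methylated aminothiazole ends, and compound 2, with two imidazole ends, sit within the scatter of each other; compound 4 combines one end of each.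

Compound 4 is therefore expected to sit near those two, with a 2.0-fold lower number from compound 3 to compound 4 (0.29 log units; within the scatter) in this assay. The estimate for compound 4 is 7 nM, range 3.5 nM to 14 nM.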

Compound 4, half-maximal effective concentration: 7.59 nM
Compound 4: the middle estimate sits 1.1-fold (0.04 log units) below what was measured, within the range that was stated.
By their numbers in this assay, from the lowest: compounds 2, 4, 1 and 3 (each within the scatter of the next, the first and the last beyond it).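

In this assay, 1H-imidazol-4-yl in place of 2-amino-1,3-thiazol-5-yl at one end gives a 1.8-fold lower number from compound 3 to compound 4 (0.26 log units; within the scatter). Exchanges between 1H-imidazol-4-yl and 2-amino-4-methyl-1,3-thiazol-5-yl at one end give a 1.2-fold higher number from compound 2 to compound 4 (0.09 log units; within the scatter) and a 1.0-fold lower number from compound 1 to compound 4 (0.01 log units; within the scatter), so the mixed compound 4 is not told apart from either compound with two matching ends, or from compound 3. No evidence bearing on these results is available.

Still open, going by these compounds, is whether a phenyl group at this end, or a shorter or longer chain joining the two carbonyl groups, would hold the number in this range.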